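Series notes: acetyl to dimethylamino on the aryl ring

The source may report more compounds than this note shows. Statements on the series, on what has been measured and on what is new or still open speak of the compounds shown alone.

compound 1 `COc1cc(C)cc(-c2c(-c3ccnc(-c4ccc(C(C)=O)cc4)c3)cnn2CC#N)c1`: 92%
compound 2 `Cc1cc(O)cc(-c2nn(CC#N)cc2-c2ccnc(-c3ccc(N(C)C)cc3)c2)c1`: 85%

In a functional assay on OVCAR-3 cells (Homo sapiens) for cytotoxicity, read by sulforhodamine B assay, with a stated time of 48 h, tested at 100 nM (a lower number here means a stronger effect, a higher number a weaker effect of the compound at the concentration tested), compound 1 gives 92%, the upper of the two numbers shown; compound 2 gives 85%, a gap within the scatter that carries no order. Compound 3 `COc1cc(C)cc(-c2c(-c3ccnc(-c4ccc(N(C)C)cc4)c3)cnn2CC#N)c1` is not yet measured. Relative to compound 1 the change is dimethylamino in place of acetyl on an aromatic carbon, on an aromatic carbon of a six-membered aromatic ring of carbon only. For the measured compounds named here, no measured pair shows this change; compound 2 carries dimethylamino but differs elsewhere too. The expected step of a number 4 percentage points lower from compound 1 to compound 3 (within the scatter) is small, not beyond the scatter. Compound 3 is expected to give 88%, in the range 70% to 100%.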

Compound 3, a percentage reported as activity, at one concentration (the size of the read-out at that concentration, not a potency): -20%
Compound 3: the middle estimate sits 108 percentage points above what was measured, outside the stated range (below it).
By their numbers in this assay, from the lowest: compound 3; then compounds 2 and 1 (each within the scatter of the next).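

In this assay, for the compounds shown here, dimethylamino in place of acetyl on the aromatic carbon gives a step of a number 112 percentage points lower from compound 1 to compound 3 (beyond the scatter), the first change at this position isolated by a matched pair. The two groups match in the heavy-atom and acceptor counts, so those counts alone do not set the read-out at this position. No available evidence explains the step.

As far as these compounds go, it remains open whether a primary amine, methoxy or diethylamino at this position would behave like dimethylamino. The compounds shown also leave open whether the step persists with other substituents elsewhere on the shared core.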